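A few compounds are considered here, and "the series" means these few. Any claim that something is new, unique, unknown or untested is made for them only; others in the source may bear on it.

Measured in an ADME assay on microsomes from liver (Mus musculus) for metabolic stability, with a stated time of 10 min; a lower number here means that less of the compound is left, a higher number that more of the compound is left:
Compound 1 `CO[C@]1(C(=O)N2CC[C@](c3ccc(C(F)(C(F)(F)F)C(F)(F)F)cc3)(S(=O)(=O)c3ccc(F)cc3)C2)CC[C@H](C(=O)O)CC1`: 95%
Compound 2 `O=C(O)C12CCC(C(=O)N3CC[C@](c4ccc(C(F)(C(F)(F)F)C(F)(F)F)cc4)(S(=O)(=O)c4ccc(F)cc4)C3)(CC1)C2`: "not determined" (no result reported)
Compound 3 `COC(=O)[C@H]1CC[C@H](C(=O)N2CC[C@](c3ccc(C(F)(C(F)(F)F)C(F)(F)F)cc3)(S(=O)(=O)c3ccc(F)cc3)C2)CC1`: "not determined" (no result reported)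

Compound 1 is the only one of the three with a number, so the series offers just one point of reference. In this assay compound 3 stands at "not determined" (no result reported), and compound 2 shares that position with "not determined" (no result reported). Among the compounds with values here, compound 3 therefore cannot be ranked against compound 1, and no measured step shows how changes to this acyl group move the read-out.

Compound 4 `CCC1(C(=O)N2CC[C@](c3ccc(C(F)(C(F)(F)F)C(F)(F)F)cc3)(S(=O)(=O)c3ccc(F)cc3)C2)CCS(=O)(=O)CC1` keeps the shared core and changes only the group on a carbonyl carbon whose other neighbours are an amide-type nitrogen in a ring: 4-ethyl-1,1-dioxothian-4-yl in place of 4-(methoxycarbonyl)cyclohexyl on a carbonyl carbon. Within the data shown here, with 4-ethyl-1,1-dioxothian-4-yl in place of 4-(methoxycarbonyl)cyclohexyl, the only anchor is compound 1 at 95%. A step from that value is expected to be small and downward, possibly no larger than the scatter, though the data cannot test this. For compound 4 the estimated value is 85%, with an expected range of 62% to 99%.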

Compound 4, percent of the compound remaining: 0%
Compound 4: the middle estimate sits 85 percentage points above what was measured, outside the stated range (below it).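

In this assay the read-out is a number 95 percentage points lower from compound 1 to compound 4 (beyond the scatter), with 4-ethyl-1,1-dioxothian-4-yl in place of 4-carboxy-1-methoxycyclohexyl on a carbonyl carbon. This first readable step shows that the shared core alone does not fix the read-out, which depends strongly on the group at this place. The steps involving compound 2 and compound 3 cannot be read, and nothing shown gives a reason for the drop.

Which feature of the exchanged groups carries the step remains open, as the two groups differ in their ring atoms and their substituents at once. As far as these compounds go, it is also open how the read-out would respond on the ring of compound 4 to an amine or to a propyl chain in place of the ethyl group.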